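The source may report more compounds than this note shows. Statements on the series, on what has been measured and on what is new or still open speak of the compounds shown alone.

Compound 1 `Cc1cc(C)cc(Cc2ccc3c(NCCCNCc4ccco4)ccnc3c2)c1` is one of three measured compounds that share a core and differ only in the group on a saturated chain carbon bound to an amine nitrogen. In a physicochemical assay for acid dissociation, compound 1 gives 9.47. Compound 2 `COc1cccc(CNCCCNc2ccnc3cc(Cc4cc(C)cc(C)c4)ccc23)c1O` gives 9.47 in this assay, and compound 3 `COc1ccc(F)cc1CNCCCNc1ccnc2cc(Cc3cc(C)cc(C)c3)ccc12` gives 9.47, so compound 1 stands level with both at the digits shown. The three steps among them, no change at the digits printed from compound 1 to compound 2 (within the scatter), no change at the digits printed from compound 1 to compound 3 (within the scatter) and no change at the digits printed from compound 2 to compound 3 (within the scatter), all fall within the scatter of the measurement.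

Compound 4 `FC(F)(F)c1cccc(Cc2ccc3c(NCCCNCc4ccco4)ccnc3c2)c1` is not yet measured. It differs from compound 1 by 3-(trifluoromethyl)phenyl in place of 3,5-dimethylphenyl on a saturated chain carbon bound to an aromatic carbon. For the measured compounds named here, none of the measured steps touches this position; all of them exchange groups on the saturated chain carbon bound to the amine nitrogen, and each leaves the acid dissociation constant unchanged within the scatter. There is thus no measured step that bears directly on the change from compound 1 to compound 4, and the data give no reason to expect a step beyond the scatter. The step of a number 0.07 log units lower from compound 1 to compound 4 (within the scatter) is accordingly expected to be small. Compound 4 is expected to give 9.4 in this assay, with a range from 9.05 to 9.75.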

Compound 4, acid dissociation constant: 9.47
Beside the measured number, compound 4's estimate is 0.07 log units below it, and the stated range covers the measured number.
By their numbers in this assay, from the lowest: compounds 1, 2, 3 and 4 (each within the scatter of the next).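

In this assay, the only step shown on the saturated chain carbon bound to an aromatic carbon, 3-(trifluoromethyl)phenyl in place of 3,5-dimethylphenyl, gives no change at the digits printed from compound 1 to compound 4 (within the scatter), although the entering group has 10 heavy atoms, three of them fluorine, against 8 carbon atoms in the group that leaves. For the compounds shown here, the earlier steps all lay on the saturated chain carbon bound to an amine nitrogen, so this is the first sign that a change at this second place can also stay within the scatter, and no step among the four compounds goes beyond it. Nothing available accounts for this result.

As far as these compounds go, both groups exchanged here are six-membered aromatic rings of carbon only with no hydrogen-bond donors or acceptors, so it remains open whether an amine or a carboxylic acid carried on that ring, or a pyridine ring in its place, would also leave the number within the scatter. Also open, from the compounds shown here alone, is whether a longer chain on the saturated chain carbon bound to an aromatic carbon would do the same.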